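The compounds below may be only part of what the source reports. "The series", "measured", "known", "first", "only" and "open" are said of these compounds alone.

Measured compounds:
- compound 1, `CCCCC/C=C\C/C=C\CCCCCCCc1cc(=O)c2c(O)cc(O)cc2o1`, in a functional assay on MCF7 cells (Homo sapiens) for antiproliferative activity, read by MTT assay (on this read-out lower numbers stand for stronger inhibition and higher numbers for weaker inhibition), gives 17500 nM
- compound 2, `CCCCC/C=C\C/C=C\CCCCCCCc1cc(=O)c2c(O)cc(OCOC)cc2o1`, in this assay gives > 67200 nM, which is a limit of the assay and not a number

Within the data shown here, compound 1 therefore stands as the only compound with a measured number; the one other value shown is a limit. Compound 3, `CCCCC/C=C\C/C=C\CCCCCCCc1cc(=O)c2c(O)cc(O)c(C)c2o1`, carries methyl in place of hydrogen on an aromatic carbon.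

One measured step exists, an at least 3.8-fold higher number from compound 1 to compound 2 (0.58 log units; beyond the scatter), and it concerns a different change, methoxymethyl in place of hydrogen on an oxygen on an aromatic ring; its size is known only through (the limit of > 67200 nM in this assay, at which 1 of the 2 values shown sits). It does not touch an aromatic carbon, so it bears on the new step only indirectly. Adding a small methyl with no donors or acceptors is expected to produce no step beyond the scatter, so the step of a 1.1-fold higher number from compound 1 to compound 3 (0.06 log units; within the scatter) is estimated as essentially flat. Compound 3 is accordingly expected to give about 20000 nM, in the range 8000 nM to 50000 nM.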

Compound 3, half-maximal inhibitory concentration: 17500 nM
Beside the measured number, compound 3's estimate is 1.1-fold (0.06 log units) above it; the measured number falls inside the stated range.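

Putting methyl in place of hydrogen on this aromatic carbon, which is ortho to a hydroxy group and ortho to a fused ring, gives no change at the digits printed from compound 1 to compound 3 (within the scatter) in this assay. Among these compounds, this carbon of the shared core therefore accepts a single added carbon atom with no loss of antiproliferative activity, something the earlier compounds could not show, as their only change sat on an oxygen and not on a ring carbon. The data shown offer no explanation of why the methyl leaves the number unmoved.

On these data alone, whether this carbon would accept anything larger or of another kind, such as an ethyl group, an amine or a carboxylic acid, remains open. So does the effect of the same methyl on the other aromatic carbons of the core.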